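Aryl for tert-butyl on a bombesin receptor subtype-3 agonist

The source may report more compounds than this note shows. Statements on the series, on what has been measured and on what is new or still open speak of the compounds shown alone.

Measured compounds:
Compound 1, `O=C(O)c1ccccc1-c1ccc(CCc2ncc(CC3CCC3)[nH]2)cc1`, gives 588 nM.
Compound 2, `O=C(O)c1ccccc1-c1ccc(CCc2ncc(Cc3ccc(Cl)cc3)[nH]2)cc1`, gives 2290 nM.
Compound 3, `CC(C)(C)Cc1cnc(CCc2ccc(-c3ccccc3C(=O)O)cc2)[nH]1`, gives 106 nM.

All three were measured in an in vitro functional assay on cells for agonist activity at Bombesin receptor subtype-3 (Homo sapiens), read by luminescence and calcium flux; a lower number here means that less compound is needed, a higher number that more compound is needed for the effect. Compound 3 has the lowest number of the three; its nearest neighbour is compound 1, and compound 2 stands furthest away. The steps among them all concern the group on a saturated chain carbon bound to an aromatic carbon: a 5.5-fold lower number from compound 1 to compound 3 (0.74 log units; beyond the scatter), a 3.9-fold higher number from compound 1 to compound 2 (0.59 log units; beyond the scatter), and a 22-fold lower number from compound 2 to compound 3 (1.33 log units; beyond the scatter).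

Compound 4, `N#Cc1cccc(Cc2cnc(CCc3ccc(-c4ccccc4C(=O)O)cc3)[nH]2)c1`, has not yet been measured. It differs from compound 3 in one place: 3-cyanophenyl in place of tert-butyl on a saturated chain carbon bound to an aromatic carbon. For the measured compounds named here, the step that bears on it most directly is the one between compound 2 and compound 3, where a six-membered aromatic ring replaced tert-butyl at this same place and gave a large rise in the number. Compound 4 likewise carries an aromatic ring there, though a different one, so a rise well beyond the scatter is expected, a 14-fold higher number from compound 3 to compound 4 (1.15 log units; beyond the scatter). Compound 4 is therefore estimated at 1500 nM, with a likely range from 400 nM to 5000 nM.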

Compound 4, half-maximal effective concentration: 812 nM
Beside the measured number, compound 4's estimate is 1.8-fold (0.27 log units) above it; low and high end bracket the measured number.
By their numbers in this assay, from the lowest: compound 3; then compounds 1 and 4 (each within the scatter of the next); then compound 2.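

In this assay, a second aromatic ring on this saturated chain carbon again raises the number relative to tert-butyl, a 7.7-fold higher number from compound 3 to compound 4 (0.88 log units; beyond the scatter), so compound 3 remains the lowest of the four and tert-butyl the best group shown at this place. The ring's substitution also matters, as 3-cyanophenyl in place of 4-chlorophenyl gives a 2.8-fold lower number from compound 2 to compound 4 (0.45 log units; beyond the scatter), so the cost of an aromatic ring here is not fixed but depends on what the ring carries. Against the saturated ring the comparison is level: 3-cyanophenyl in place of cyclobutyl gives a 1.4-fold higher number from compound 1 to compound 4 (0.14 log units; within the scatter), so at this place the cyano-bearing aromatic ring cannot be told apart from cyclobutyl in this assay.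

Because 3-cyanophenyl and 4-chlorophenyl differ in both the substituent and its place on the ring, the compounds shown cannot separate those two changes, and 4-cyanophenyl, 3-chlorophenyl or plain phenyl at this place would be needed to do so. Nothing available here explains why any of these groups gives the number it does.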